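A few compounds are considered here, and "the series" means these few. Any claim that something is new, unique, unknown or untested is made for them only; others in the source may bear on it.

In a functional assay for inhibition, with Homo sapiens as the target (a lower number here means a stronger inhibitor, a higher number a weaker inhibitor), compound 1 `CCOC(=O)C(=O)N(c1ccccc1)c1nccc(-c2ccncc2)n1` gives 2200 nM. That is the second highest of the three numbers shown: compound 2 `CCc1cccc(Nc2nccc(-c3ccccn3)n2)c1` gives 1400 nM, a difference within the usual scatter, while compound 3 `CCc1cccc(Nc2nccc(-c3ccncc3)n2)c1` gives 10600 nM, beyond it. Among the compounds with values here, the one measured step, a 7.6-fold higher number from compound 2 to compound 3 (0.88 log units; beyond the scatter), concerns a change on the other ring and says nothing about the change examined here. Compound 4 `CN(c1ccccc1)c1nccc(-c2ccncc2)n1` differs from compound 1 in that (methyl in place of (ethoxycarbonyl)carbonyl on a nitrogen on an aromatic ring). Within the data shown here, no measured pair tests this exchange, so the direction is open. Compound 4 is therefore expected to sit near compound 1, at an estimated 3500 nM with a range from 700 nM to 18000 nM, meaning an expected step of a 1.6-fold higher number from compound 1 to compound 4 (0.20 log units; within the scatter).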

Compound 4, half-maximal inhibitory concentration: > 24000 nM
Compound 4 was reported as a limit; the forecaster's own chance of this, stated with the estimate: 10%; middle value at least 6.8-fold (0.83 log units) away from the limit.
By their numbers in this assay, from the lowest: compounds 2 and 1 (each within the scatter of the next); then compound 3. At a limit, above all of these: compound 4.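

Within the data shown here, on a nitrogen on an aromatic ring, this is the first measured exchange, and in this assay replacing (ethoxycarbonyl)carbonyl with methyl gives a large step: an at least 10-fold higher number from compound 1 to compound 4 (1.03 log units; beyond the scatter). Compound 4 is reported only as a limit: the limit of > 24000 nM in this assay, at which 1 of the 4 values shown sits. The group on this nitrogen therefore matters, and methyl does not preserve the activity of compound 1.

The compounds shown leave open which part of the (ethoxycarbonyl)carbonyl group counts. An acetyl group or a free carboxylic acid end on this nitrogen would help separate the carbonyl from the ethyl ester.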